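The source may report more compounds than this note shows. Statements on the series, on what has been measured and on what is new or still open speak of the compounds shown alone.

Working notes on the series. Of the compounds shown here, two have been measured so far: compound 1 `COc1cc(C)c(-c2cccc(COc3ccc4c(c3)SCC4CC(=O)O)c2)c(C)c1` and compound 2 `O=C(O)CS(=O)(=O)c1ccc(OCc2cccc(-c3ccccc3)c2)cc1`. In a functional assay on CHO cells for agonist activity at Free fatty acid receptor 1 (Homo sapiens), read by FLIPR and calcium flux (a lower number here means that less compound is needed, a higher number that more compound is needed for the effect), compound 1 gives 123 nM, and in this assay compound 2 gives 288 nM. Compound 2 therefore stands at the higher of the two numbers, and the gap to compound 1 is beyond the usual scatter. Within the data shown here, the two compounds differ in several places at once, so no single step between them can be stated; only what their two values show is known.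

Compound 3 `Cc1ccc(-c2cccc(COc3ccc(S(=O)(=O)CC(=O)O)cc3)c2)c(Cl)c1` is the next compound to be measured in this assay. It differs from compound 2 in one place: 2-chloro-4-methylphenyl in place of phenyl on an aromatic carbon. Among the measured compounds shown here, no pair of measured compounds differs in this place alone, so there is no measured step to lean on. The only pointer is loose: the aromatic group that in compound 3 gains its chlorine and methyl carries substituents in compound 1 as well, and compound 1 gives the lower number 123 nM. The expected step of a 2.2-fold lower number from compound 2 to compound 3 (0.35 log units; beyond the scatter) is a modest fall that may not clear the scatter. Compound 3 is expected to give 130 nM, within 45 nM to 400 nM.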

Compound 3, half-maximal effective concentration: 36.3 nM
Estimate against measurement, compound 3: 3.6-fold (0.55 log units) above, and the stated range ends above it.
By their numbers in this assay, from the lowest: compound 3; then compound 1; then compound 2.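

In this assay, among these compounds, the exchange of phenyl for 2-chloro-4-methylphenyl gives a 7.9-fold lower number from compound 2 to compound 3 (0.90 log units; beyond the scatter), the first step that can be tied to one place, on an aromatic carbon meta to a large group. The two earlier compounds differ in several places at once and could not show that this place alone moves the number beyond the scatter; the step now shows that it does, with the hydrogen-bond donor and acceptor counts of the entering and leaving groups the same and neither group carrying a net charge. Nothing available explains the size of this step.

As far as these compounds go, the chlorine and the methyl enter together, so the share of each in the step stays unknown, and it is equally open whether a phenyl carrying only one of them, or a trifluoromethyl or a nitrile in place of the chlorine, would give a step of similar size. Also open, from the compounds shown here alone, is whether the 2-chloro-4-methylphenyl group would give a comparable step on the core of compound 1.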